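Benzyl amine variation on the shared core

The source may report more compounds than this note shows. Statements on the series, on what has been measured and on what is new or still open speak of the compounds shown alone.

Measured so far:
compound 1 `Nc1cc(N)c2nc(-c3ccccc3)c(NCc3ccc(Cl)c(Cl)c3)nc2c1` — < 100000 nM
compound 2 `CCOC(=O)[C@H](CCC(=O)O)NC(=O)c1ccc(Sc2nc3cc(N)cc(N)c3nc2-c2ccccc2)cc1` — < 100000 nM

In a functional assay on CAKI-1 cells (Homo sapiens) for inhibition, read by sulforhodamine B assay, with a stated time of 48 h (a lower number here means that less compound is tolerated, a higher number that more compound is tolerated), compound 1 gives < 100000 nM, which is a limit of the assay and not a number. Compound 2 gives < 100000 nM in this assay, again a limit. Among the compounds with values here, both values sit at the limit of < 100000 nM in this assay, at which 2 of the 2 values shown sit, so no measured step between them can be drawn. Compound 3 `COc1ccc(CNc2nc3cc(N)cc(N)c3nc2-c2ccccc2)cc1` differs from compound 1 by 4-methoxyphenyl in place of 3,4-dichlorophenyl on a saturated chain carbon bound to a nitrogen on an aromatic ring. Within the data shown here, no measured step speaks to this change, and the step that the limit leaves unreadable from compound 1 to compound 3 is expected to stay within the scatter. Compound 3 is thus estimated at 30000 nM, in a range from 5000 nM to 100000 nM.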

Compound 3, concentration lethal to 50% of the cells: 79400 nM
Compound 3: middle estimate off by 2.6-fold (0.42 log units), on the low side; the measured number falls inside the stated range.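

No step from compound 1 to compound 3 can be read, as the value of compound 1 is a limit and not a number: the limit of < 100000 nM in this assay, at which 2 of the 3 values shown sit.

The compounds shown leave open how 3,4-dichlorobenzyl and 4-methoxybenzyl compare on the shared core.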